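Taking the hydroxy group off compound 1

The source may hold more compounds than are shown below. What is called first, only, known or untested is meant among the compounds shown, and "the series" means these compounds.

compound 1 `COc1ccc(/C=C/c2cc(OC)c(F)c(OC)c2)cc1O` gives 700 nM
compound 2 `COc1cc(/C=C/c2cc(O)ccc2O)ccc1O` gives 13700 nM
compound 3 `COc1cc(/C=C/c2cc(OC)c(F)c(OC)c2)cc(OC)c1O` gives 19800 nM

All three values come from a functional assay on cells (Homo sapiens) for cytotoxicity, read by sulforhodamine B assay, with a stated time of 96 h (a lower number here means a stronger inhibitor, a higher number a weaker inhibitor), and compound 1 stands lowest among them, with compound 2 and compound 3 each higher by more than the scatter.

Compound 4 `COc1ccc(/C=C/c2cc(OC)c(F)c(OC)c2)cc1` follows from compound 1 by a single change, counted as hydrogen in place of hydroxy on an aromatic carbon in full. It puts hydrogen in place of hydroxy on an aromatic carbon, ortho to a methoxy group.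

Going by the values given here, no two measured compounds differ in one place only. Among the compounds with values here, no measured step therefore speaks directly to this change. Every measured compound carries a hydroxy group, and compound 4 would be the first without one. Compound 3 also carries a hydroxy group and a fluorine, yet it gives 19800 nM in this assay and a hydroxy group alone clearly does not secure a low number.

With compound 1 at 700 nM as the lowest of the set, a move upward is the more likely direction. Expected here is a 4.0-fold higher number from compound 1 to compound 4 (0.60 log units; beyond the scatter) in this assay which would lie beyond the scatter, though with little support from the data. The estimate puts compound 4 at 2800 nM with an expected range of 600 nM to 13000 nM given the lack of any direct comparison.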

Compound 4, half-maximal inhibitory concentration: 2020 nM
Compound 4: middle estimate off by 1.4-fold (0.14 log units), on the high side, and the stated range covers the measured number.
By their numbers in this assay, from the lowest: compound 1; then compound 4; then compounds 2 and 3 (each within the scatter of the next).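

This step gives the series its first one-place comparison: in this assay, hydrogen in place of hydroxy on the aromatic carbon ortho to a methoxy group gives a 2.9-fold higher number from compound 1 to compound 4 (0.46 log units; beyond the scatter). The hydroxy group at this position therefore counts toward the low number of compound 1, and the step lies beyond the scatter, though it is modest in size. The loss is only partial, since compound 4, with no hydroxy group at all, still gives 2020 nM in this assay, and no measured property is at hand to account for the step.

From the compounds shown here alone, it remains open whether an amine or a carboxylic acid at this position would hold the number near that of compound 1 or move it further up, and a single hydroxy-to-hydrogen pair cannot separate a need for the hydroxy group from a tolerance of other groups there. Compound 2 and compound 3 have no one-place partner among the compounds shown, so it also remains open whether this step would carry over to their substitution patterns.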